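This account rests on a few compounds, and the source may have more. Where it says the series, first, only, none or still open, it means among the compounds named here.

Series notes on the shared core of compound 1 `Nc1cc(N)c2nc(-c3ccccc3)c(Oc3ccc(Cl)c(Cl)c3)nc2c1` and its partners. In a functional assay on ACHN cells (Homo sapiens) for inhibition, read by sulforhodamine B assay, with a stated time of 48 h (a lower number here means a stronger inhibitor of growth, a higher number a weaker inhibitor of growth), compound 1 gives 47900 nM. Going by the values given here, this is the higher of the two numbers measured in this assay so far; the only other entry, compound 2 `CCOC(=O)[C@H](CCC(=O)O)NC(=O)c1ccc(Oc2nc3cc(N)cc(N)c3nc2-c2ccccc2)cc1`, gives 11200 nM in this assay, and the gap between the two numbers lies beyond the usual scatter. Among the compounds with values here, no single-point step between measured compounds is available, so no measured step can anchor the next change.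

Compound 3 `Nc1cc(N)c2nc(-c3ccccc3)c(Oc3ccc(F)cc3)nc2c1` is the next member to be measured in this assay. The change from compound 1 to compound 3 is 4-fluorophenyl in place of 3,4-dichlorophenyl on an oxygen on an aromatic ring. The two measured compounds differ at the same oxygen but in more than one place, so they say nothing directly about this swap.

The expected step in this assay from compound 1 to compound 3 is a 1.3-fold higher number from compound 1 to compound 3 (0.10 log units; within the scatter), a small move toward a weaker inhibitor of growth that may well stay within the scatter. The estimate for compound 3 in this assay is 60000 nM, with a range from 25000 nM to 150000 nM.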

Compound 3, concentration for total growth inhibition: 33100 nM
For compound 3 the middle estimate is 1.8-fold (0.26 log units) above the measured one; low and high end bracket the measured number.
By their numbers in this assay, from the lowest: compound 2; then compounds 3 and 1 (each within the scatter of the next).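

In this assay, the series now has its first single-point step, a 1.4-fold lower number from compound 1 to compound 3 (0.16 log units; within the scatter), on an oxygen on an aromatic ring. The step lies within the scatter, so this assay does not separate 4-fluorophenyl from 3,4-dichlorophenyl at this position, even though the swap changes both the halogen and the number of halogens on the ring. No measurement shown here offers an explanation for this result, and none is assigned to either group.

From the compounds shown here alone, what remains open is whether this position tolerates groups further from these two halogenated phenyl rings, such as an unsubstituted phenyl, a 4-methoxyphenyl, a pyridyl ring or a cyclohexyl group on the same oxygen. Going by these compounds alone, compound 2 still differs from compound 1 and compound 3 in more than one place, so the single change that goes with its lower number in this assay cannot be read from these compounds, and a simple benzoic acid or benzamide at this oxygen would be needed to divide that difference into separate steps.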